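Dropping one chloro from the sulfonyl aryl of compound 1

The source may hold more compounds than are shown below. What is called first, only, known or untested is meant among the compounds shown, and "the series" means these compounds.

Compound 1 `O=S(=O)(NCCCCCCNCc1ccc(Br)cc1)c1c(Cl)cccc1Cl` stands highest of the three numbers in a functional assay on MIA PaCa-2 cells (Homo sapiens) for inhibition, read by MTT assay, with a stated time of 72 h; on this read-out higher numbers stand for weaker inhibition of growth and lower numbers for stronger inhibition of growth: compound 1 gives 14700 nM. Nearest to it is compound 3 `O=S(=O)(NCCCCCCNCc1ccc(Br)cc1)c1c(Cl)cc(C(F)(F)F)cc1Cl`, which in this assay gives 5670 nM; furthest is compound 2 `O=S(=O)(NCCCNCc1ccc(Br)cc1)c1cc(C(F)(F)F)cc(C(F)(F)F)c1`, which carries a shorter chain and a different aryl and gives 2300 nM. Among the compounds with values here, the one single-point step within the set, a 2.6-fold lower number from compound 1 to compound 3 (0.41 log units; beyond the scatter), adds a trifluoromethyl to the sulfonyl aryl of compound 1 and lowers the number modestly.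

Compound 4 `O=S(=O)(NCCCCCCNCc1ccc(Br)cc1)c1ccccc1Cl` differs from compound 1 by hydrogen in place of chloro on an aromatic carbon; read one bond further out, the change is 2,6-dichlorophenyl to 2-chlorophenyl. Within the data shown here, no measured step removes a group from this ring, so nothing in the set bears on it directly. Among the measured compounds shown here, the only step in hand went the other way, adding a group to the aryl and lowering the number; taking a group away is therefore expected to leave the number where it is or raise it somewhat, by a step no larger than that one. Compound 4 is expected at 22000 nM, within a range of 9000 nM to 55000 nM, which means an estimated step of a 1.5-fold higher number from compound 1 to compound 4 (0.18 log units; within the scatter) that may well lie within the scatter.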

Compound 4, concentration for 50% growth inhibition: 13700 nM
Estimate against measurement, compound 4: 1.6-fold (0.21 log units) above; the range from low to high includes it.
By their numbers in this assay, from the lowest: compound 2; then compound 3; then compounds 4 and 1 (each within the scatter of the next).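

In this assay, hydrogen in place of chloro on an aromatic carbon, the change from 2,6-dichlorophenyl to 2-chlorophenyl, gives a 1.1-fold lower number from compound 1 to compound 4 (0.03 log units; within the scatter), so this chloro, ortho to a large group, can be lost with no change in the number beyond the usual scatter. Within the data shown here, this is the first step that removes a group from the sulfonyl aryl, and it differs in outcome from the one earlier step on that ring, a 2.6-fold lower number from compound 1 to compound 3 (0.41 log units; beyond the scatter), where the trifluoromethyl on another carbon moved the number beyond the scatter. Nothing at hand speaks to why the two changes on this ring read differently.

The compounds shown leave open whether the remaining chloro can go as well, which a plain phenyl on the sulfonyl would answer, and whether a methoxy or an amino group on the freed carbon would leave the number unchanged. They also leave open whether the same loss of chloro reads alike with the shorter chain of compound 2.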